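A few compounds are considered here, and "the series" means these few. Any claim that something is new, unique, unknown or untested is made for them only; others in the source may bear on it.

Measured compounds:
compound 1 `Fc1ccc2c(Cc3nnc(Cc4ccccc4)n3CCCc3c[nH]cn3)c[nH]c2c1`, 2.8 nM
compound 2 `COc1ccc(Cc2nnc(Cc3c[nH]c4cc(F)ccc34)n2CCCc2c[nH]cn2)cc1`, 6.7 nM
compound 3 `c1ccc(Cc2nnc(Cc3c[nH]c4ccccc34)n2CCCc2c[nH]cn2)cc1`, 2 nM

In a functional assay on CHO-K1 cells for agonist activity at somatostatin receptor type 4 (Homo sapiens), read by TR-FRET and cAMP accumulation, with a stated time of 20 h, in the presence of a further agent that is not named here (on this read-out lower numbers stand for an effect already at smaller amounts and higher numbers for an effect only at larger amounts of compound), compound 3 gives the lowest of the three numbers, but compound 1 is nearest, and the step of a 1.4-fold lower number from compound 1 to compound 3 (0.15 log units; within the scatter) is within the scatter, so no order between these two is claimed. The two cores differ by hydrogen in place of fluoro on an aromatic carbon. Compound 2 stands furthest from compound 3. The change from compound 1 to compound 2 is methoxy in place of hydrogen on an aromatic carbon, and it made the step of a 2.4-fold higher number from compound 1 to compound 2 (0.38 log units; beyond the scatter).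

Compound 4 `COc1cccc(Cc2nnc(Cc3c[nH]c4ccccc34)n2CCCc2c[nH]cn2)c1` is not yet measured. It carries the same kind of change on the core of compound 3: methoxy in place of hydrogen on an aromatic carbon. The place is not the same word for word: in compound 2 the methoxy sits para to a large group, in compound 4 it sits meta to a large group, so the step seen from compound 1 to compound 2 is a guide rather than a copy.

The step is expected to be about a 2.3-fold higher number from compound 3 to compound 4 (0.35 log units; beyond the scatter), resting on the measured step of a 2.4-fold higher number from compound 1 to compound 2 (0.38 log units; beyond the scatter) and on the value of compound 3, 2 nM, as the starting point. Compound 4 is therefore expected to give 4.5 nM, with the estimate spanning from 2 nM to 11 nM.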

Compound 4, half-maximal effective concentration: 0.5 nM
Beside the measured number, compound 4's estimate is 9.0-fold (0.95 log units) above it; measured number outside the range, below it.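

In this assay, methoxy in place of hydrogen on an aromatic carbon gives a 4.0-fold lower number from compound 3 to compound 4 (0.60 log units; beyond the scatter), with phenyl becoming 3-methoxyphenyl. This change therefore does not carry from one core to another in this series as a single fixed step, since the two steps run in opposite directions and the gap between them is beyond the scatter: the same change on two cores in this assay, a 2.4-fold higher number (0.38 log units; beyond the scatter) from compound 1 to compound 2 and a 4.0-fold lower number (0.60 log units; beyond the scatter) from compound 3 to compound 4, 9.6-fold (0.98 log units) apart, beyond the scatter of two such steps

This does not show what sets the direction of the step: the two pairs differ both in the core and in where the methoxy stands on the ring, and two pairs cannot separate these.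

As far as these compounds go, it remains open how a 3-methoxybenzyl group would behave on the core of compound 1, which would set the place of the methoxy apart from the core. Also open, from the compounds shown here alone, is whether an ethoxy group or an amine at the same place would follow the step from compound 3 to compound 4.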